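Opening the Pyrrolidine Ring to Diethylamino

The source may report more compounds than this note shows. Statements on the series, on what has been measured and on what is new or still open speak of the compounds shown alone.

In a functional assay on MGC-803 cells (Homo sapiens) for cytotoxicity, read by MTT assay, with a stated time of 38 h (on this read-out higher numbers stand for weaker inhibition and lower numbers for stronger inhibition), compound 2 `COc1cc(OC)c2c(=O)c(OCCCN3CCCC3)c(-c3cc(OC)c(OC)c(OC)c3)oc2c1` gives 32100 nM. Compound 1 `COc1cc(OC)c2c(=O)c(OCCCCN3CCCC3)c(-c3cc(OC)c(OC)c(OC)c3)oc2c1` gives 18600 nM, which lies within the usual scatter of the value for compound 2, so the two cannot be ranked against each other. For the measured compounds named here, these are the only two numbers available so far.

Compound 3 `CCN(CC)CCCOc1c(-c2cc(OC)c(OC)c(OC)c2)oc2cc(OC)cc(OC)c2c1=O` shares its core and chain with compound 2 and differs in one group: diethylamino in place of pyrrolidin-1-yl on a saturated chain carbon, three bonds along the chain from an oxygen on an aromatic ring. A ring thus gives way to an open group, diethylamino in place of pyrrolidin-1-yl.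

Going by the values given here, one measured step bears on this, and only indirectly: a 1.7-fold higher number from compound 1 to compound 2 (0.24 log units; within the scatter). That step altered the chain, left the pyrrolidin-1-yl group untouched and stayed within the scatter. Among the compounds with values here, no measured pair swaps a ring for an open group, so the data point in neither direction. In this assay, no step beyond the scatter is therefore expected, and the estimated change is a 1.2-fold lower number from compound 2 to compound 3 (0.08 log units; within the scatter). For compound 3 the estimated value is 27000 nM, with an expected range of 12000 nM to 60000 nM.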

Compound 3, half-maximal inhibitory concentration: 40200 nM
The estimate for compound 3 lay 1.5-fold (0.17 log units) below the measured number; measured number inside the range.
By their numbers in this assay, from the lowest: compounds 1, 2 and 3 (each within the scatter of the next, the first and the last beyond it).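

In this assay, opening the ring gives a 1.3-fold higher number from compound 2 to compound 3 (0.10 log units; within the scatter), so at this place on the chain a ring and an open group with the same count of heavy atoms cannot be told apart; a ring is not shown to matter here. For the compounds shown here, the wider comparison gives a 2.2-fold higher number from compound 1 to compound 3 (0.33 log units; beyond the scatter), the first step in this set to pass the scatter, though only modestly, and it joins two changes that each stay within the scatter when read alone: the pyrrolidin-1-yl group becomes diethylamino, and the chain carrying it differs as well. Nothing measured here explains these numbers or says what the swap does to the compounds.

The compounds shown leave open how a 4-(diethylamino)butyl chain would compare with compound 1, a comparison that would show whether the chain or the amine accounts for the modest step. They also leave open whether a piperidine ring, a morpholine ring or a smaller open amine such as dimethylamino, placed on the same saturated chain carbon, would stay within the scatter of compound 2 or move clearly away from it.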